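The source may report more compounds than this note shows. Statements on the series, on what has been measured and on what is new or still open speak of the compounds shown alone.

Measured so far:
- compound 1, `S=C=Nc1ccc(CCC2=NCCN2)cc1`: 107%
- compound 2, `S=C=Nc1ccc(OCC2=NCCN2)cc1`: 108%
- compound 3, `Cc1ccc(CC2=NCCN2)cc1`: 14%

All three compounds share a five-membered ring with two nitrogens joined by a short linker to a substituted aromatic ring. In an ADME assay on the whole organism (thoracic aorta) with Rattus norvegicus as the target (on this read-out higher numbers stand for larger maximal responses and lower numbers for smaller maximal responses), compound 1 reaches 107% and compound 2 reaches 108%; these two values lie within the usual scatter of each other. Compound 3, the only one of the three with a methyl group on its aromatic ring, gives 14% and stands lowest of the three, far below both others, by an amount well beyond the scatter.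

The next compound, compound 4, `O=C(CI)Nc1ccc(CC2=NCCN2)cc1`, has not yet been tested. Compared with compound 3 it differs in one place: ((iodomethyl)carbonyl)amino in place of methyl on an aromatic carbon. Both of the high-responding compounds, compound 1 and compound 2, carry something other than methyl on the aromatic ring, while compound 3 with methyl alone gives the low value. With only these three points there is no way to tell how much of the high response depends on the exact group, so the expectation for compound 4 is uncertain but leans upward.

The expected step in this assay is a number 51 percentage points higher from compound 3 to compound 4 (beyond the scatter), a clear rise beyond the scatter. Compound 4 is therefore estimated at 65%, in a range from 20% to 105%.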

Compound 4, largest response reached (Emax), in percent of the reference or control that the assay uses: 25%
Compound 4: middle estimate off by 40 percentage points, on the high side; the measured number falls inside the stated range.
By their numbers in this assay, from the lowest: compound 3; then compound 4; then compounds 1 and 2 (each within the scatter of the next).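

In this assay, putting ((iodomethyl)carbonyl)amino in place of methyl on this aromatic carbon gives a number 11 percentage points higher from compound 3 to compound 4 (beyond the scatter), a modest rise that still lies beyond the usual scatter. Within the data shown here, this is the first direct reading at this position, since compound 3 and compound 4 differ only in this one group, so the effect of the change can be seen apart from the rest of the molecule. Five heavy atoms replace one, and a hydrogen-bond donor and a hydrogen-bond acceptor enter, yet the maximal response moves only this modest distance; no measurement at hand explains the size of this rise.

The compounds shown cannot separate the parts of the new group, so it stays open whether the rise goes with the iodine or with the amide unit that carries it; an acetylamino group, the same unit with plain methyl in place of iodomethyl, would pull these two apart. On these data alone, it also stays open how a simple amine or a carboxylic acid on this same aromatic carbon would compare with methyl on the shared core.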